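The source may hold more compounds than are shown below. What is called first, only, known or untested is meant among the compounds shown, and "the series" means these compounds.

Compound 1 `CCOC(=O)N1CCC(NS(=O)(=O)c2ccc(O)c3ccccc23)CC1`: in an assay on L1.2 cells for binding affinity to C-C chemokine receptor type 8 (Homo sapiens) (on this read-out higher numbers stand for weaker inhibition and lower numbers for stronger inhibition), compound 1 reports only a limit, > 5000 nM.
Compound 2 `CCC(=O)N1CCC(NS(=O)(=O)c2ccc(NC(=O)c3ccccc3C)c3ccccc23)CC1`: in this assay compound 2 gives 2.5 nM.

Among the compounds with values here, compound 2 therefore holds the only number in this assay; the other entry is the limit of > 5000 nM in this assay, at which 1 of the 2 values shown sits, so no step between measured compounds can be drawn. Compound 3 `COCC(=O)N1CCC(NS(=O)(=O)c2ccc(NC(=O)c3ccccc3C)c3ccccc23)CC1` differs from compound 2 by methoxy in place of methyl on a saturated chain carbon bound to a carbonyl carbon. Nothing measured bears on that change, so the expected step from compound 2 to compound 3 is a 1.6-fold higher number from compound 2 to compound 3 (0.20 log units; within the scatter), which is not beyond the scatter. Compound 3 is accordingly estimated at 4 nM, with a likely range from 1.2 nM to 15 nM.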

Compound 3, inhibition constant: 15.8 nM
For compound 3 the middle estimate is 4.0-fold (0.60 log units) below the measured one; measured number above the stated range.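

Methoxy in place of methyl on a saturated chain carbon bound to a carbonyl carbon gives a 6.3-fold higher number from compound 2 to compound 3 (0.80 log units; beyond the scatter) in this assay, so this position does respond to a change in its group. Within the data shown here, this is the first step read between compounds that differ in one place, and compound 3 keeps a low number on this read-out despite the step. Nothing measured here accounts for the step.

Going by these compounds, whether the same step would come with a longer chain such as ethyl in place of methyl stays open. So does the outcome with a hydroxyl or an amine such as dimethylamino at this place.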